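The source may report more compounds than this note shows. Statements on the series, on what has been measured and on what is new or still open speak of the compounds shown alone.

Compound 1 `C/C(=C\Cc1c(O)ccc2c1O[C@H](c1ccc(O)cc1)CC2=O)C/C=C/C(C)(C)O` gives in a functional assay on MCF7 cells (Homo sapiens) for cytotoxicity, read by MTT assay (a higher number here means a weaker inhibitor, a lower number a stronger inhibitor), only a limit, > 10000 nM.
Compound 2 `C=C(C)C(O)CC/C(C)=C/Cc1c(O)ccc2c1O[C@H](c1ccc(O)cc1)CC2=O` gives in this assay only a limit, > 10000 nM.
Compound 3 `C=C(CCC=C(C)C)C(O)Cc1c(O)ccc2c1O[C@H](c1ccc(O)cc1)CC2=O` gives in this assay only a limit, > 10000 nM.

Compound 3 therefore stands where the other two measured compounds stand: at the limit of this assay, with no number of its own. Among the measured compounds shown here, none of the measured steps can be read, since (the limit of > 10000 nM in this assay, at which 3 of the 3 values shown sit). The step that the two limits leave unreadable from compound 1 to compound 2, the step that the two limits leave unreadable from compound 1 to compound 3 and the step that the two limits leave unreadable from compound 2 to compound 3 all pass between two limits, so none of them shows whether exchanging one 10-heavy-atom side chain for another moves the read-out at all.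

Compound 4 `CC1=CCC(O)C(C)(C)C1Cc1c(O)ccc2c1O[C@H](c1ccc(O)cc1)CC2=O` differs from compound 3 in that the side chain is closed into a ring: a group of 10 heavy atoms (9 carbon, 1 oxygen; one six-membered non-aromatic ring of carbon only) in place of a group of 10 heavy atoms (9 carbon, 1 oxygen; no ring), on a saturated chain carbon bound to an aromatic carbon. The three measured steps all concern changes of the same kind at the same place, a saturated chain carbon bound to an aromatic carbon, and none of them revealed a change that reached below the limit. The account therefore expects compound 4 to behave like compound 3, with the step that the limit leaves unreadable from compound 3 to compound 4 expected to be no more than the scatter, and most likely again a limit. For compound 4 the expected value in this assay is 20000 nM, with a range from 8000 nM to 100000 nM.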

Compound 4, half-maximal inhibitory concentration: > 10000 nM
Compound 4: no number, only a limit; the forecaster's own chance of this, stated with the estimate: 80%; the middle value lies beyond the limit too.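

Compound 4 gives in this assay only a limit, > 10000 nM. Its steps from compound 1, compound 2 and compound 3 therefore cannot be read: the limit of > 10000 nM in this assay, at which 4 of the 4 values shown sit. The compounds shown leave open whether any of these side chains, open or closed into a ring, changes the read-out at all.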